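This account rests on a few compounds, and the source may have more. Where it says the series, first, only, none or still open, it means among the compounds named here.

Among the compounds with values here, compound 1 `COc1cc(Nc2ncc(C(F)(F)F)c(N3Cc4cccc(N(C)S(C)(=O)=O)c4C3)n2)c(OC)cc1Cl` gives, in a functional assay on HeLa cells (Homo sapiens) for antiproliferative activity, read by spectrophotometry, with a stated time of 2 days (a higher number here means a weaker inhibitor of growth, a lower number a stronger inhibitor of growth), 16500 nM, the only actual number among the three measured compounds. Compound 2 `CN(c1cccc2c1CN(c1nc(Nc3ccc(C(F)(F)F)cc3)ncc1C(F)(F)F)C2)S(C)(=O)=O` reaches only the limit > 30000 nM in this assay. Compound 3 `Cc1cc(C)cc(Nc2ncc(C(F)(F)F)c(N3Cc4cccc(N(C)S(C)(=O)=O)c4C3)n2)c1` likewise ends at the limit > 30000 nM. Compound 4 `CN(c1cccc2c1CN(c1nc(Nc3cccc(C(F)(F)F)c3)ncc1C(F)(F)F)C2)S(C)(=O)=O` carries the change (3-(trifluoromethyl)phenyl in place of 4-chloro-2,5-dimethoxyphenyl on a nitrogen on an aromatic ring). The measured steps that bear on it are an at least 1.8-fold higher number from compound 1 to compound 2 (0.25 log units; that floor lies within the scatter) and an at least 1.8-fold higher number from compound 1 to compound 3 (0.25 log units; that floor lies within the scatter), each running into the limit (the limit of > 30000 nM in this assay, at which 2 of the 3 values shown sit). Both replacements of the same group thus left weaker growth inhibition by at least that amount, and a similar outcome is expected for compound 4. The step from compound 1 is estimated as a 2.1-fold higher number from compound 1 to compound 4 (0.33 log units; beyond the scatter). Compound 4 is expected to give about 35000 nM, within 12000 nM to 100000 nM.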

Compound 4, concentration for 50% growth inhibition: 5300 nM
Compound 4: the middle estimate sits 6.6-fold (0.82 log units) above what was measured; the whole stated range lies above it.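

In this assay, replacing the 4-chloro-2,5-dimethoxyphenyl group need not weaken growth inhibition, since 3-(trifluoromethyl)phenyl gives a 3.1-fold lower number from compound 1 to compound 4 (0.49 log units; beyond the scatter). The result also depends on which trifluoromethylphenyl group is present, with an at least 5.6-fold lower number from compound 2 to compound 4 (0.75 log units; beyond the scatter), while exchanging 3,5-dimethylphenyl for 3-(trifluoromethyl)phenyl gives an at least 5.6-fold lower number from compound 3 to compound 4 (0.75 log units; beyond the scatter). These last two steps are only minimum sizes, as each starts from a limit rather than a number: the limit of > 30000 nM in this assay, at which 2 of the 4 values shown sit.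

Going by these compounds, it remains open whether a nitrile or a carboxylic acid in place of the trifluoromethyl group would keep this growth inhibition. On these data alone, whether a phenyl ring is needed at all is also open, and an amine such as piperidine on the shared core would test that.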